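Pyrrolyl hydrazone in the adenosine hydrazone series

This account rests on a few compounds, and the source may have more. Where it says the series, first, only, none or still open, it means among the compounds named here.

The shared core is the hydrazinyl nucleoside seen in compound 1 `Nc1nc(N/N=C/c2ccc(OCc3ccc(F)cc3)cc2)nc2c1ncn2[C@@H]1O[C@H](CO)[C@@H](O)[C@H]1O`, compound 2 `CCOc1cc(/C=N/Nc2nc(N)c3ncn([C@@H]4O[C@H](CO)[C@@H](O)[C@H]4O)c3n2)ccc1O` and compound 3 `Nc1nc(N/N=C/c2ccc(C(F)(F)F)cc2C(F)(F)F)nc2c1ncn2[C@@H]1O[C@H](CO)[C@@H](O)[C@H]1O`, with the arylidene group varied. In an assay on CHO-K1 cells for displacement of a labelled ligand from adenosine receptor A1 (Homo sapiens), read by scintillation counting, with a stated time of 60 min (on this read-out higher numbers stand for weaker inhibition and lower numbers for stronger inhibition), compound 1 gives 70 nM. In this assay compound 2 gives 6940 nM, the higher of the two numbers, and the gap to compound 1 is well beyond the scatter. For compound 3 the result in this assay is a limit, > 10000 nM; this is the limit of > 10000 nM in this assay, at which 1 of the 3 values shown sits.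

Compound 4 `Nc1nc(N/N=C/c2ccc[nH]2)nc2c1ncn2[C@@H]1O[C@H](CO)[C@@H](O)[C@H]1O` is not yet measured. It differs from compound 2 by 1H-pyrrol-2-yl in place of 3-ethoxy-4-hydroxyphenyl on a carbon with a double bond to nitrogen. Among the compounds with values here, no pair differing in one place has been measured, so the size of the step has to be estimated from the spread of the three numbers alone. The expectation is a step from compound 2 to compound 4 of a 2.0-fold lower number from compound 2 to compound 4 (0.30 log units; within the scatter) in this assay, towards a somewhat lower number but not clearly beyond the scatter. Compound 4 is therefore estimated at 3500 nM in this assay, with a range from 500 nM to 15000 nM.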

Compound 4, inhibition constant: 8 nM
Compound 4: middle estimate off by 440-fold (2.64 log units), on the high side, and the stated range ends above it.
By their numbers in this assay, from the lowest: compound 4; then compound 1; then compound 2. At a limit, above all of these: compound 3.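

In this assay, the exchange of the arylidene group gives an 870-fold lower number from compound 2 to compound 4 (2.94 log units; beyond the scatter) and is the only step shown between compounds that differ in one place. It shows that the number at this position can move a long way with a single change of group, and that a six-membered aromatic ring of carbon only is not required here. The entering group has fewer heavy atoms and the same count of hydrogen-bond donors, and nothing measured here gives a reason for the size of this step.

This single step does not separate the change of ring from the loss of the ethoxy and hydroxyl groups. Also open, going by these compounds, is where an unsubstituted phenyl, a furyl or a thienyl group would fall at this position in this assay.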